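The compounds below may be only part of what the source reports. "The series", "measured", "known", "first", "only" and "open" are said of these compounds alone.

In a functional assay on HL-60 cells (Homo sapiens) for cytotoxicity, read by WST assay, with a stated time of 48 h (a lower number here means that less compound is needed, a higher number that more compound is needed for the effect), compound 1 (`Cc1ccccc1C[C@H]1C(=O)OC[C@@H]1Cc1ccccc1`) gives 57000 nM and compound 2 (`O=C1OC[C@H](Cc2ccccc2O)[C@H]1Cc1ccc(Cl)c(Cl)c1`) gives 33000 nM. Compound 3 (`CCOc1ccccc1C[C@H]1COC(=O)[C@@H]1Cc1ccc(Cl)c(Cl)c1`) gives 15000 nM, the lowest number of the three.

The next structure is compound 4 (`Cc1ccccc1C[C@H]1COC(=O)[C@@H]1Cc1ccc(Cl)c(Cl)c1`). Its difference from compound 3 is methyl in place of ethoxy on an aromatic carbon, with methyl in place of ethoxy on an aromatic carbon, ortho to a large group.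

Going by the values given here, one measured step bears on this directly: a 2.2-fold lower number from compound 2 to compound 3 (0.34 log units; beyond the scatter), a modest change made with ethyl in place of hydrogen on the oxygen that compound 4 no longer carries. Compound 1 also bears a methyl group, but it differs from compound 4 in more than that group, so compound 1, at 57000 nM, is weak guidance. Among the compounds with values here, no measured pair isolates methyl against ethoxy.

A small rise in this assay is therefore expected, possibly none beyond the scatter. The expected step is a 1.3-fold higher number from compound 3 to compound 4 (0.12 log units; within the scatter). For compound 4 the estimated value is 20000 nM, with an expected range of 9000 nM to 45000 nM.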

Compound 4, half-maximal effective concentration: 22000 nM
The estimate for compound 4 lay 1.1-fold (0.04 log units) below the measured number; the measured number falls inside the stated range.
By their numbers in this assay, from the lowest: compounds 3, 4, 2 and 1 (each within the scatter of the next, the first and the last beyond it).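

In this assay, methyl in place of ethoxy on this aromatic carbon, ortho to a large group, gives a 1.5-fold higher number from compound 3 to compound 4 (0.17 log units; within the scatter) and methyl in place of hydroxy gives a 1.5-fold lower number from compound 2 to compound 4 (0.18 log units; within the scatter) in the same series. Methyl therefore cannot be separated from either oxygen-bearing group, and the only step at this position beyond the scatter remains a 2.2-fold lower number from compound 2 to compound 3 (0.34 log units; beyond the scatter), between hydroxy and ethoxy. The ethoxy oxygen, the one hydrogen-bond acceptor that leaves with this change, is not shown to matter for the number, and nothing available explains these small differences.

On these data alone, whether an amine or a carboxylic acid on this aromatic carbon would move the number beyond the scatter of the methyl compound stays open. So does the outcome of a longer chain, such as butoxy, at this place.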